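Nitro in place of hydrogen on a thiosemicarbazone

The source may report more compounds than this note shows. Statements on the series, on what has been measured and on what is new or still open speak of the compounds shown alone.

Measured compounds:
compound 1 `COc1ccc(/C=N/NC(=S)NC(C)(C)[C@H]2CC=C(C)CC2)cc1`: 43800 nM
compound 2 `CC1=CC[C@H](C(C)(C)NC(=S)N/N=C(\C)c2ccccc2)CC1`: > 100000 nM

In a functional assay on NCI/ADR-RES cells (Homo sapiens) for inhibition, read by sulforhodamine B assay, with a stated time of 48 h (a lower number here means a stronger inhibitor of growth, a higher number a weaker inhibitor of growth), compound 1 gives 43800 nM. For compound 2 the assay reports only a limit, > 100000 nM, so compound 2 stands at the limit of > 100000 nM in this assay, at which 1 of the 2 values shown sits, and no number is known for it. Compound 3 `CC1=CC[C@H](C(C)(C)NC(=S)N/N=C(\C)c2ccc([N+](=O)[O-])cc2)CC1` differs from compound 2 by nitro in place of hydrogen on an aromatic carbon. Among the compounds with values here, no measured step between two compounds points in either direction here, so the account of compound 3 rests on the limit alone. The expected step of an at least 1.2-fold lower number from compound 2 to compound 3 (0.09 log units; that floor lies within the scatter) is small, if any beyond the scatter. Compound 3 is estimated at 80000 nM, between 20000 nM and 300000 nM.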

Compound 3, concentration for 50% growth inhibition: 9900 nM
Compound 3: middle estimate off by 8.1-fold (0.91 log units), on the high side; the measured number lies below the stated range.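

In this assay, nitro in place of hydrogen on an aromatic carbon, para to a large group, gives an at least 10-fold lower number from compound 2 to compound 3 (1.00 log units; beyond the scatter). Within the data shown here, this is the first measured step, and it shows that a change at this position of the six-membered aromatic ring can move the number beyond the scatter. The true size of the step remains unknown, because compound 2 has only a limit: the limit of > 100000 nM in this assay, at which 1 of the 3 values shown sits.

The compounds shown leave open whether an amine, a nitrile or a chlorine atom at this place would also lower the number. They also leave open whether nitro on another ring carbon would do so.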